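This account rests on a few compounds, and the source may have more. Where it says the series, first, only, none or still open, it means among the compounds named here.

In a functional assay on V79-379A cells (Cricetulus griseus) for cytotoxicity, read by MTT assay, in the presence of a further agent that is not named here (on this read-out lower numbers stand for stronger inhibition and higher numbers for weaker inhibition), compound 1 `COC1=CC(=O)c2c(c(CO)c(C3CC3)n2C)C1=O` gives 540000 nM and compound 2 `COC1=CC(=O)c2c(c(COC(=O)c3ccc(F)cc3)cn2C)C1=O` gives 700 nM as its value. Compound 3 `COC1=CC(=O)c2c(c(COC(=O)c3ccc(F)cc3)c(C)n2C)C1=O` stands between them at 27000 nM and so holds the second highest of the three numbers. Compound 4 `COC1=CC(=O)c2c(c(COC(C)=O)c(C)n2C)C1=O` follows from compound 3 by one change, methyl in place of 4-fluorophenyl on a carbonyl carbon. Among the measured compounds shown here, no measured step covers this change. For the measured compounds named here, the only measured step, methyl in place of hydrogen on an aromatic carbon, gives a 39-fold higher number from compound 2 to compound 3 (1.59 log units; beyond the scatter) and is large, yet compound 3 and compound 4 both already carry that methyl. Going by the values given here, compound 1 differs from compound 3 in more than one place, so it sets no size for this step. With so little to go on, a 1.5-fold higher number from compound 3 to compound 4 (0.17 log units; within the scatter) is the expected step in this assay and it would stay within the scatter, though with wide uncertainty. The estimate for compound 4 is 40000 nM with an expected range from 10000 nM to 150000 nM on this read-out.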

Compound 4, half-maximal inhibitory concentration: 27000 nM
Compound 4: middle estimate off by 1.5-fold (0.17 log units), on the high side, and the stated range covers the measured number.
By their numbers in this assay, from the lowest: compound 2; then compounds 3 and 4 (each within the scatter of the next); then compound 1.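

In this assay the new step reads no change at the digits printed from compound 3 to compound 4 (within the scatter), so with the aromatic-carbon methyl in place, the 4-fluorophenyl on the carbonyl carbon and methyl cannot be told apart. Among the compounds shown here, this is the first step read at this carbonyl carbon, and it shows that the six-membered aromatic ring is not needed to keep the number of compound 3 in this assay. No supporting measurement bears on this result, so it stands without an explanation.

As far as these compounds go, the step is read only on compounds carrying that methyl, so whether the same exchange would hold on compound 2, which has hydrogen on that aromatic carbon and gives 700 nM, remains open. From the compounds shown here alone, how a longer chain such as butyl, an amine or a carboxylic acid would read on this carbonyl carbon also remains open.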